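Bromo for chloro at a second place in the series

A few compounds are considered here, and "the series" means these few. Any claim that something is new, unique, unknown or untested is made for them only; others in the source may bear on it.

Measured so far:
Compound 1 `O=C(Nc1ccc(C(F)(F)F)cc1)c1ccc(Cl)cc1O` gives 1180 nM.
Compound 2 `O=C(Nc1ccc(C(F)(F)F)cc1)c1ccc(Br)cc1O` gives 690 nM.
Compound 3 `O=C(Nc1ccc(Cl)c(Cl)c1)c1cc(F)ccc1O` gives 1370 nM.

All three numbers come from a functional assay on NALM-6 cells (Homo sapiens) for cytotoxicity, read by luminescence and CellTiter-Glo, with a stated time of 3 days; a lower number here means a stronger inhibitor, a higher number a weaker inhibitor. Among the compounds with values here, the one counted change among the measured compounds is bromo in place of chloro on an aromatic carbon, and it made the step of a 1.7-fold lower number from compound 1 to compound 2 (0.23 log units; within the scatter). Compound 3 stands on a different core; how its core differs from that of compound 1 is not broken down here. Its value in this assay lies within the scatter of both compound 1 and compound 2, so no order among the three can be read.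

Compound 4 `O=C(Nc1ccc(Br)c(Cl)c1)c1cc(F)ccc1O` is the unmeasured member. It arises from compound 3 by bromo in place of chloro on an aromatic carbon. Within the data shown here, this is the same kind of change as the one from compound 1 to compound 2, not the same: there the place was meta to a hydroxy group, here it is ortho to a chloro group, both para to a large group.

The expected step of a 1.4-fold lower number from compound 3 to compound 4 (0.14 log units; within the scatter) is set beside a 1.7-fold lower number from compound 1 to compound 2 (0.23 log units; within the scatter), because that step from compound 1 to compound 2 stayed within the scatter, and nothing measured speaks for a larger shift here. Compound 4 is therefore estimated at 1000 nM, between 450 nM and 2200 nM.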

Compound 4, half-maximal inhibitory concentration: 1250 nM
Estimate against measurement, compound 4: 1.3-fold (0.10 log units) below; the measured number falls inside the stated range.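

In this assay, bromo in place of chloro on an aromatic carbon gives a 1.1-fold lower number from compound 3 to compound 4 (0.04 log units; within the scatter), so on this second core the change again stays within the scatter. Set side by side, the two steps do not differ: the same change on two cores in this assay, a 1.7-fold lower number (0.23 log units; within the scatter) from compound 1 to compound 2 and a 1.1-fold lower number (0.04 log units; within the scatter) from compound 3 to compound 4, 1.6-fold (0.19 log units) apart, within the scatter of two such steps

This shows that the change carried from one core to the other without a step beyond the scatter on either, although the place on the ring is not the same in the two pairs. Within the data shown here, it does not show that bromo and chloro are interchangeable across the series, since two pairs fix no rule and neither step is large enough to read a direction from.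

The compounds shown leave open whether a different group in that place, such as a nitrile, a methoxy or an amine, would move the number beyond the scatter. They also leave open what a methoxy in place of the hydroxy group would do on either core.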